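Swapping the pyridin-4-yl amino end for thiazolyl

This account rests on a few compounds, and the source may have more. Where it says the series, first, only, none or still open, it means among the compounds named here.

Compound 1 `O=C(Nc1ccncc1)Nc1cc(-c2cccnc2)cc(C(F)(F)F)c1` gives > 300000 nM in a functional assay on A549 cells (Homo sapiens) for inhibition, read by MTT assay, with a stated time of 48 h (on this read-out lower numbers stand for stronger inhibition and higher numbers for weaker inhibition), which is a limit of the assay and not a number. Compound 2 `O=C(Nc1ccncc1)Nc1cc(-c2cncnc2)cc(C(F)(F)F)c1` gives 2420 nM in this assay. Among the measured compounds shown here, the only measured step, an at least 120-fold lower number from compound 1 to compound 2 (2.09 log units; beyond the scatter), is large and is made at another place, with pyrimidin-5-yl in place of pyridin-3-yl on an aromatic carbon. Compound 3 `O=C(Nc1cc(-c2cccnc2)cc(C(F)(F)F)c1)Nc1nccs1` keeps the pyridin-3-yl of compound 1 and carries 1,3-thiazol-2-yl in place of pyridin-4-yl on an amide-type nitrogen. That step therefore bears only indirectly, and a moderate move to a lower number is expected, estimated as an at least 10-fold lower number from compound 1 to compound 3 (1.00 log units; beyond the scatter). For compound 3 the expected value is 30000 nM, within an estimated range of 4000 nM to 300000 nM.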

Compound 3, half-maximal inhibitory concentration: 92100 nM
The estimate for compound 3 lay 3.1-fold (0.49 log units) below the measured number; measured number inside the range.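

At the amide-type nitrogen, 1,3-thiazol-2-yl in place of pyridin-4-yl gives an at least 3.2-fold lower number from compound 1 to compound 3 (0.51 log units; beyond the scatter) in this assay, so this place also moves the number while pyridin-3-yl stays fixed. The step is a bound and not a size, as it rests on a limit of the assay: the limit of > 300000 nM in this assay, at which 1 of the 3 values shown sits.

Compound 3 gives a number with pyridin-3-yl kept, so that group alone does not hold the series at the limit. On these data alone, whether 1,3-thiazol-2-yl and pyrimidin-5-yl together give a lower number than either change alone remains open. So does the effect of a phenyl or a simple alkyl amine at the amide-type nitrogen.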